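Removing the pyridine nitrogen from the amide side of a modulator

This account rests on a few compounds, and the source may have more. Where it says the series, first, only, none or still open, it means among the compounds named here.

The compounds share one core, an amide linked to a pyrazole that carries two phenyl groups, and differ only in the group on the carbonyl carbon. In a functional assay on cells for positive allosteric modulation of metabotropic glutamate receptor 5 (Rattus norvegicus), read by calcium flux (a lower number here means that less compound is needed, a higher number that more compound is needed for the effect), compound 1 `O=C(Nc1cc(-c2ccccc2)nn1-c1ccccc1)c1cccc(C(F)(F)F)c1` gives 228 nM. Among the measured compounds shown here, compound 2 `O=C(Nc1cc(-c2ccccc2)nn1-c1ccccc1)c1ccncc1` gives 2500 nM in this assay, the highest of the two numbers so far; its nearest neighbour is compound 1, and the step of an 11-fold higher number from compound 1 to compound 2 (1.04 log units; beyond the scatter) shows how far the two lie apart.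

Compound 3 `O=C(Nc1cc(-c2ccccc2)nn1-c1ccccc1)C1=CCCCC1` follows from compound 2 through (cyclohex-1-en-1-yl in place of pyridin-4-yl on a carbonyl carbon). For the measured compounds named here, the only measured step that bears on this position is an 11-fold higher number from compound 1 to compound 2 (1.04 log units; beyond the scatter), where an aromatic ring without a heteroatom stood against one with a ring nitrogen. A ring without heteroatoms, though now non-aromatic, is expected to bring the number part of the way back, so a moderate downward step a 2.1-fold lower number from compound 2 to compound 3 (0.32 log units; beyond the scatter) is estimated. For compound 3 the estimate in this assay is 1200 nM, within a range from 300 nM to 5000 nM.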

Compound 3, half-maximal effective concentration: 3300 nM
The estimate for compound 3 lay 2.8-fold (0.44 log units) below the measured number; low and high end bracket the measured number.
By their numbers in this assay, from the lowest: compound 1; then compounds 2 and 3 (each within the scatter of the next).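

In this assay, the step of a 1.3-fold higher number from compound 2 to compound 3 (0.12 log units; within the scatter) leaves pyridin-4-yl and cyclohex-1-en-1-yl indistinguishable on the carbonyl carbon, so a six-membered ring of carbon only does not by itself recover the lower number of compound 1. The step of a 14-fold higher number from compound 1 to compound 3 (1.16 log units; beyond the scatter) is about as large as the one seen earlier with pyridin-4-yl, which means that the ring nitrogen alone cannot be what separates compound 2 from compound 1 in these data: compound 3 has no ring nitrogen and still lies far from compound 1. No measurement is at hand that would explain why these two groups give such similar numbers.

Compound 3 differs from compound 1 both in losing the aromatic ring and in losing the trifluoromethyl group, so the compounds shown cannot say which of the two goes with the lower number of compound 1. An unsubstituted phenyl on the carbonyl carbon would separate these two changes, and a saturated cyclohexyl would show whether the double bond of cyclohex-1-en-1-yl matters at all.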